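The source may hold more compounds than are shown below. What is called first, only, known or untested is meant among the compounds shown, and "the series" means these compounds.

Measured compounds:
compound 1 `Cc1c(O)ccc2c1[C@H](Cn1cc(-c3ccc(F)cc3)nn1)[C@@]13CC(=O)[C@@](C)(CC[C@@H]21)C3` — in a functional assay on SMMC-7721 cells (Homo sapiens) for cytotoxicity, read by MTT assay, with a stated time of 4 days (a higher number here means a weaker inhibitor, a lower number a stronger inhibitor), compound 1 gives > 20000 nM, a limit of the assay and not a number.
compound 2 `Cc1ccc(S(=O)(=O)Oc2ccc3c(c2C)[C@H](Cn2cc(-c4ccc(F)cc4)nn2)[C@@]24CC(=O)[C@@](C)(CC[C@@H]32)C4)cc1` — compound 2 gives > 20000 nM, likewise a limit.

Both values sit at the limit of > 20000 nM in this assay, at which 2 of the 2 values shown sit, so the step that the two limits leave unreadable from compound 1 to compound 2 cannot be read. Compound 1 thus stands only at a limit, with no numbered value in the shared core series. Compound 3 `COc1ccc(-c2cn(C[C@H]3c4c(ccc(O)c4C)[C@@H]4CC[C@@]5(C)C[C@]43CC5=O)nn2)cc1` differs from compound 1 by methoxy in place of fluoro on an aromatic carbon. Going by the values given here, no measured step bears on this change. The expectation for compound 3 is that it too stays at the limit, estimated at 35000 nM with a range from 10000 nM to 120000 nM, a step that the limit leaves unreadable from compound 1 to compound 3 expected to remain unreadable.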

Compound 3, half-maximal inhibitory concentration: > 20000 nM
Compound 3: only a limit was reported (the forecaster's own chance of this, stated with the estimate: 85%); the middle value is on the limit's open side.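

Compound 3 gives > 20000 nM, a limit and not a number. Going by these compounds alone, compound 1 also stands at a limit, so no step from compound 1 to compound 3 can be read: the limit of > 20000 nM in this assay, at which 3 of the 3 values shown sit. The compounds shown leave open which change to the shared core, if any, would give a numbered value.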